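From 4-Methylphenyl to 3,4-Dimethylphenyl: One Added Methyl

The compounds below may be only part of what the source reports. "The series", "measured", "known", "first", "only" and "open" are said of these compounds alone.

Compound 1, `COc1cc2c(Nc3ccc(NC(=O)Nc4cccc(Cl)c4)cc3)ncnc2cc1OCc1ccccc1`, in a functional assay on MCF7 cells (Homo sapiens) for antiproliferative activity, read by MTT assay, with a stated time of 48 h; a higher number here means a weaker inhibitor, a lower number a stronger inhibitor: > 50000 nM, a limit of the assay.
Compound 2, `COc1cc2c(Nc3ccc(NC(=O)Nc4ccc(C)cc4)cc3)ncnc2cc1OCc1ccccc1`, in this assay: > 50000 nM, a limit of the assay.

Compound 2 therefore stands at a limit of this assay and not at a number. The same holds for compound 1, since (the limit of > 50000 nM in this assay, at which 2 of the 2 values shown sit). Among the measured compounds shown here, the one step between measured compounds, a step that the two limits leave unreadable from compound 1 to compound 2, is consequently not readable, and it carries no size that could be transferred.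

Compound 3, `COc1cc2c(Nc3ccc(NC(=O)Nc4ccc(C)c(C)c4)cc3)ncnc2cc1OCc1ccccc1`, differs from compound 2 by methyl in place of hydrogen on an aromatic carbon. For the measured compounds named here, no measured step bears on this change: the only step available, from compound 1 to compound 2, shows nothing beyond two limits. What can be carried over is that both measured compounds, sharing the same core, fail to reach a measurable value in this assay.

Compound 3 is accordingly expected to remain at the limit of this assay as well, with an estimate of 60000 nM, the range spanning 20000 nM to 200000 nM. The step that the limit leaves unreadable from compound 2 to compound 3 is expected to be unreadable in the same way as the step already measured.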

Compound 3, half-maximal inhibitory concentration: > 50000 nM
Compound 3 gave a limit, no number (the forecaster's own chance of this, stated with the estimate: 80%); the middle value does not contradict the limit.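

In this assay compound 3 gives > 50000 nM and this is a limit of the assay, not a number. Its steps from compound 1 and from compound 2 therefore cannot be read, and all three compounds share one limit: the limit of > 50000 nM in this assay, at which 3 of the 3 values shown sit.

The compounds shown leave open how far past that limit each one lies, and whether any compound on the shared core reaches a measurable value in this assay under some other change.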